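A few compounds are considered here, and "the series" means these few. Any claim that something is new, unique, unknown or untested is made for them only; others in the source may bear on it.

In an assay on COS-7 cells for inhibition of patatin-like phospholipase domain-containing protein 2 (Mus musculus), tested at 200 uM (on this read-out lower numbers stand for less inhibition and higher numbers for more inhibition at the one concentration tested (going by the name of the read-out)), compound 2 `COC(=O)Nc1cccc(-c2ccc(N(C)C)cc2)c1` gives 95%, the higher of the two values recorded, while compound 1 `CCOC(=O)c1cccc(-c2ccc(N(C)C)cc2)c1` gives 87%. Going by the values given here, the one measured step is a number 8 percentage points higher from compound 1 to compound 2 (within the scatter), a change at the same position as the one now considered. Compound 3 `CN(C)C(=O)N(C)c1cccc(-c2ccc(N(C)C)cc2)c1` differs from compound 2 by (dimethylcarbamoyl)(methyl)amino in place of (methoxycarbonyl)amino on an aromatic carbon. That earlier step gives little guidance for this larger change; inhibition is expected to stay substantial, though somewhat lower is possible, so the step from compound 2 to compound 3 is estimated at a number 10 percentage points lower from compound 2 to compound 3 (within the scatter). Compound 3 is therefore expected to reach 85%, within 60% to 98%.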

Compound 3, a percentage reported as inhibition, at one concentration (the size of the read-out at that concentration, not a potency): 74%
Compound 3: the middle estimate sits 11 percentage points above what was measured, within the range that was stated.
By their numbers in this assay, from the lowest: compound 3; then compounds 1 and 2 (each within the scatter of the next).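

This position is not indifferent to what sits on it: (dimethylcarbamoyl)(methyl)amino gives a number 21 percentage points lower from compound 2 to compound 3 (beyond the scatter) and also a number 13 percentage points lower from compound 1 to compound 3 (beyond the scatter) while the earlier step on this aromatic carbon stayed within the scatter. Even so, compound 3 still gives 74% of inhibition, so this larger group costs only a modest part of the effect. Nothing available here accounts for the drop. As far as these compounds go, whether the methyl on the nitrogen or the dimethylcarbamoyl part drives the step stays open, as does how a primary amine or a carboxylic acid would fare on this carbon.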